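Swapping the chloro for a methyl on the anilide ring

A few compounds are considered here, and "the series" means these few. Any claim that something is new, unique, unknown or untested is made for them only; others in the source may bear on it.

Measured so far in a functional assay on the whole organism (strain Wistar) for inhibition, with Rattus norvegicus as the target, read by paw edema, with a stated time of 2 h, at a dose of 100 mg/kg; a lower number here means less inhibition, a higher number more inhibition at the dose given (going by the name of the read-out):
compound 1, `COc1cc2c(cc1OC)C(CC(=O)Nc1ccccc1)CC2`, 32%
compound 2, `COc1cc2c(cc1OC)C(CC(=O)Nc1ccc(Cl)cc1)CC2`, 63%
compound 3, `COc1cc2c(cc1OC)C(CC(=O)Nc1ccc(Br)cc1)CC2`, 40%

Compound 2 stands highest of the three numbers in this assay. Its nearest neighbour is compound 3, and the step of a number 23 percentage points lower from compound 2 to compound 3 (beyond the scatter) is beyond the scatter; compound 1 sits furthest away, with a number 31 percentage points higher from compound 1 to compound 2 (beyond the scatter) marking a large gain on putting chloro onto the phenyl. The bromo analogue, by contrast, moves little from the parent: a number 8 percentage points higher from compound 1 to compound 3 (within the scatter) stays within the scatter.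

Compound 4, `COc1cc2c(cc1OC)C(CC(=O)Nc1cccc(C)c1)CC2`, has not been measured. It differs from compound 2 in one place: 3-methylphenyl in place of 4-chlorophenyl on an amide-type nitrogen. Going by the values given here, no measured compound carries a methyl, so the two steps that bear on this change are those that alter the halogen: the large gain from compound 1 to compound 2 and the modest loss from compound 2 to compound 3. Both show that what sits on the anilide ring matters, and that the chloro of compound 2 is the only substituent so far tied to a high number. Taking the chloro away therefore points downward, toward the number of compound 1, while the methyl itself is an unknown.

Compound 4 is expected to give about 40%, in a range from 25% to 58%. That estimate means an expected step of a number 23 percentage points lower from compound 2 to compound 4 (beyond the scatter).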

Compound 4, a percentage reported as inhibition, in the whole organism at one dose (the size of the read-out at that dose, not a potency): 29%
Compound 4: the middle estimate sits 11 percentage points above what was measured; low and high end bracket the measured number.
By their numbers in this assay, from the lowest: compounds 4, 1 and 3 (each within the scatter of the next, the first and the last beyond it); then compound 2.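

In this assay the methyl of the 3-methylphenyl group gives no lift over the unsubstituted anilide, since a number 3 percentage points lower from compound 1 to compound 4 (within the scatter) and the methyl compound stays level with the parent. So a substituent on this ring does not by itself bring a high number, and a number 34 percentage points lower from compound 2 to compound 4 (beyond the scatter) shows how much of the standing of compound 2 is lost once the 4-chlorophenyl group goes. The bromo compound also separates from the methyl compound, with a number 11 percentage points lower from compound 3 to compound 4 (beyond the scatter) even though neither the bromo nor the methyl compound is beyond the scatter of compound 1; nothing measured here speaks to the reason for any of these steps.

Compound 4 changes both the substituent and its place on the ring relative to compound 2, so the compounds shown cannot say whether the loss belongs to the methyl, to where it sits, or to both. As far as these compounds go, how a fluoro, a methoxy or a trifluoromethyl group on the anilide ring would compare with the chloro also stays open, and with it whether the chloro of compound 2 is a lone high point.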